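The source may report more compounds than this note shows. Statements on the series, on what has been measured and on what is new or still open speak of the compounds shown alone.

Values in a functional assay for inhibition, with Homo sapiens as the target (a higher number here means a weaker inhibitor, a lower number a stronger inhibitor), so far
- compound 1 `O=C(NC[C@H](NS(=O)(=O)c1cccnc1)C(=O)O)c1cc2cc(CCC3CCNCC3)sc2s1` gives 8 nM
- compound 2 `O=C(NC[C@H](NS(=O)(=O)c1cccnc1)C(=O)O)c1cc2cc(CC3CCNCC3)sc2s1` gives 23 nM
- compound 3 `O=C(NC[C@H](NS(=O)(=O)c1cccs1)C(=O)O)c1cc2cc(CCC3CCNCC3)sc2s1` gives 9 nM

In this assay compound 3 (9 nM) lies within the scatter of compound 1, while compound 2 (23 nM) shows the higher number, beyond the scatter of both.

Next is compound 4 `O=C(NC[C@H](NS(=O)(=O)c1ccccc1)C(=O)O)c1cc2cc(CCC3CCNCC3)sc2s1`, which carries phenyl in place of thiophen-2-yl on a sulfonyl sulfur.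

For the measured compounds named here, the one measured step at this place is the change from pyridin-3-yl to thiophen-2-yl (a 1.1-fold higher number from compound 1 to compound 3 (0.05 log units; within the scatter)), which is within the scatter. The other step (a 2.9-fold higher number from compound 1 to compound 2 (0.46 log units; beyond the scatter)) is a modest one on the chain and does not bear on the sulfonyl group. Going by the values given here, no phenyl compound has been measured yet, so the evidence is a single swap.

The expected change is no step beyond the scatter (no change at the digits printed from compound 3 to compound 4 (within the scatter)), with no firm direction. Compound 4 is estimated at 9 nM with an expected range of 4.5 nM to 20 nM in this series.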

Compound 4, half-maximal inhibitory concentration: 8 nM
Compound 4: middle estimate off by 1.1-fold (0.05 log units), on the high side, and the stated range covers the measured number.
By their numbers in this assay, from the lowest: compounds 1, 4 and 3 (each within the scatter of the next); then compound 2.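

In this assay, the ring on the sulfonyl sulfur can be carbon only without leaving the scatter: a 1.1-fold lower number from compound 3 to compound 4 (0.05 log units; within the scatter), and no change at the digits printed from compound 1 to compound 4 (within the scatter). Pyridin-3-yl, thiophen-2-yl and phenyl thus all read alike at this place, so across these compounds the hetero atom of the two earlier rings makes no difference beyond the scatter, and ring size, five-membered or six-membered, makes none either. Nothing available explains this flat reading.

Open, on these data alone, is whether the reading holds for a phenyl ring carrying a methoxy group or a carboxylic acid, or for a non-aromatic group such as methyl or cyclohexyl on the sulfonyl sulfur. Also open, as far as these compounds go, is whether the three rings still read alike when paired with the piperidin-4-yl group of compound 2.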